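The compounds below may be only part of what the source reports. "The series", "measured", "known", "first", "only" and "open" are said of these compounds alone.

Compound 1 `CC(C)[C@H](NC(=O)COc1cccc2ccccc12)C(=O)N[C@@H](CC(=O)O)C(=O)COc1ccc(C(F)(F)F)cc1` holds the lowest of the three numbers in a functional assay with Homo sapiens as the target (on this read-out higher numbers stand for weaker inhibition and lower numbers for stronger inhibition), where compound 1 gives 12300 nM. Compound 2 `CC(C)[C@H](NC(=O)COc1cccc2ccccc12)C(=O)N[C@@H](CC(=O)O)C(=O)COc1ccc(Oc2ccccc2)cc1` gives 19000 nM and compound 3 `CC(C)[C@H](NC(=O)COc1cccc2ccccc12)C(=O)N[C@@H](CC(=O)O)C(=O)COc1ccc(Oc2ccc(C(F)(F)F)cc2)cc1` gives 24900 nM. The steps of a 1.5-fold higher number from compound 1 to compound 2 (0.19 log units; within the scatter) and a 2.0-fold higher number from compound 1 to compound 3 (0.31 log units; beyond the scatter) both replace the trifluoromethyl on the aromatic carbon, by phenoxy or by 4-(trifluoromethyl)phenoxy, and the step of a 1.3-fold higher number from compound 2 to compound 3 (0.12 log units; within the scatter) adds a trifluoromethyl. Compound 4 `CC(C)[C@H](NC(=O)COc1cccc2ccccc12)C(=O)N[C@@H](CC(=O)O)C(=O)COc1cc(F)cc(F)c1` differs from compound 1 at the aryl group on the oxygen: 3,5-difluorophenyl in place of 4-(trifluoromethyl)phenyl on an oxygen on a saturated carbon. The measured steps all alter this same aryl group and moved the number only a little, so the step of a 1.2-fold higher number from compound 1 to compound 4 (0.09 log units; within the scatter) is expected to stay near the scatter, if anything towards a higher number. Compound 4 is therefore estimated at 15000 nM, with a range of 6000 nM to 40000 nM.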

Compound 4, half-maximal inhibitory concentration: 15900 nM
Estimate against measurement, compound 4: 1.1-fold (0.03 log units) below; the range from low to high includes it.
By their numbers in this assay, from the lowest: compounds 1, 4, 2 and 3 (each within the scatter of the next, the first and the last beyond it).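

The step to the smaller aryl group, a 1.3-fold higher number from compound 1 to compound 4 (0.11 log units; within the scatter), shows that the oxygen on the saturated carbon tolerates a reduction as well as the enlargements seen earlier. Removing the trifluoromethyl altogether and placing fluorine on the ring also leaves the number within the scatter. Nothing available explains this tolerance. Open, as far as these compounds go, is whether an amine or a carboxylic acid on this aryl ring would shift the number beyond the scatter. Also open, from the compounds shown here alone, is whether a saturated alkyl chain in place of the aryl group would do so.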